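Estimating compound 4 from one analogous measured step

The source may hold more compounds than are shown below. What is called first, only, known or untested is meant among the compounds shown, and "the series" means these compounds.

Measured compounds:
compound 1 `CC(=O)OC/C(=C\C1CCCCC1)C(=O)c1ccccc1` gives 21000 nM
compound 2 `CC(=O)OC/C(=C\c1ccc(Cl)cc1)C(=O)c1ccccc1` gives 3200 nM
compound 3 `CC(=O)OC/C(=C\C1CCCCC1)C(=O)c1ccc(Cl)cc1` gives 24000 nM

In a functional assay on HeLa cells (Homo sapiens) for inhibition, read by sulforhodamine B assay, with a stated time of 48 h (a higher number here means a weaker inhibitor of growth, a lower number a stronger inhibitor of growth), compound 3 gives 24000 nM, the highest of the three numbers shown. Compound 1 stands nearest to it, and the step of a 1.1-fold higher number from compound 1 to compound 3 (0.06 log units; within the scatter) lies within the scatter, so the two cannot be ordered. Compound 2 stands furthest away, its number being well separated from that of compound 3.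

Compound 4 `CC(=O)OC/C(=C\c1ccc(Cl)cc1)C(=O)c1ccc(Cl)cc1` differs from compound 3 by 4-chlorophenyl in place of cyclohexyl on a double-bonded chain carbon bound to a double-bonded chain carbon. Going by the values given here, one measured step bears directly on this change: a 6.6-fold lower number from compound 1 to compound 2 (0.82 log units; beyond the scatter), which is the same exchange carried out on the core without chloro on the aromatic ring of the benzoyl part. That step lies beyond the scatter and points toward lower numbers. Because a 1.1-fold higher number from compound 1 to compound 3 (0.06 log units; within the scatter) stays within the scatter, the chloro present in compound 3 is not expected to alter the outcome of the exchange much, so a step of similar size is expected in this assay, namely a 6.3-fold lower number from compound 3 to compound 4 (0.80 log units; beyond the scatter). Compound 4 is therefore expected to give about 3800 nM, with a range from 1500 nM to 9500 nM.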

Compound 4, concentration for 50% growth inhibition: 19000 nM
For compound 4 the middle estimate is 5.0-fold (0.70 log units) below the measured one; the measured number lies above the stated range.
By their numbers in this assay, from the lowest: compound 2; then compounds 4, 1 and 3 (each within the scatter of the next).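

In this assay, the exchange of cyclohexyl for 4-chlorophenyl on a double-bonded chain carbon bound to a double-bonded chain carbon does not carry over from one core to the other: with chloro on the aromatic ring of the benzoyl part, it gives only a 1.3-fold lower number from compound 3 to compound 4 (0.10 log units; within the scatter), and the two steps differ clearly: the same change on two cores in this assay, a 6.6-fold lower number (0.82 log units; beyond the scatter) from compound 1 to compound 2 and a 1.3-fold lower number (0.10 log units; within the scatter) from compound 3 to compound 4, 5.2-fold (0.72 log units) apart, beyond the scatter of two such steps. Chloro in place of hydrogen on an aromatic carbon, silent on the core carrying cyclohexyl, proves to matter on the core carrying 4-chlorophenyl, with a 5.9-fold higher number from compound 2 to compound 4 (0.77 log units; beyond the scatter), so its outcome also depends on the core: the same change on two cores in this assay, a 1.1-fold higher number (0.06 log units; within the scatter) from compound 1 to compound 3 and a 5.9-fold higher number (0.77 log units; beyond the scatter) from compound 2 to compound 4, 5.2-fold (0.72 log units) apart, beyond the scatter of two such steps. The two changes therefore cannot be treated as independent here, and among these four compounds the lower number is found only in compound 2, which combines 4-chlorophenyl with a benzoyl ring free of chloro.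

Whether this dependence is specific to chloro remains open, since the compounds shown do not tell how a methoxy or an amino group in its place on the benzoyl ring would behave. Going by these compounds, it is equally open whether a group other than 4-chlorophenyl, such as unsubstituted phenyl, would show the same dependence on the benzoyl ring.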